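Aminomethyl variation on the bromo-isatin-type core

The source may report more compounds than this note shows. Statements on the series, on what has been measured and on what is new or still open speak of the compounds shown alone.

The series carries a shared core with differing amine substituents on a saturated chain carbon bound to an amide-type nitrogen in a ring. Compound 1 `CCN(CC)CN1C(=O)/C(=N\c2nc3ccc(C)cc3s2)c2c(Br)cccc21` gives 30200 nM in a functional assay on MCF7 cells (Homo sapiens) for cytotoxicity, read by sulforhodamine B assay, with a stated time of 48 h; on this read-out higher numbers stand for weaker inhibition of growth and lower numbers for stronger inhibition of growth. For the measured compounds named here, compound 2 `Cc1ccc2nc(/N=C3\C(=O)N(CN(C)C)c4cccc(Br)c43)sc2c1` gives 18000 nM in this assay; the change a 1.7-fold lower number from compound 1 to compound 2 (0.22 log units; within the scatter) is the only measured step at this position. Compound 3 `CN(C)CN1C(=O)C(=O)c2c(Br)cccc21` gives 57600 nM in this assay, the highest of the three numbers shown: against compound 1 the gap lies within the scatter, against compound 2 it lies beyond it.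

Compound 4 `O=C1C(=O)N(CN2CCCCC2)c2cccc(Br)c21` differs from compound 3 by piperidin-1-yl in place of dimethylamino on a saturated chain carbon bound to an amide-type nitrogen in a ring. Going by the values given here, the one measured step that bears on this change is the swap between compound 1 and compound 2 at the same place, which stayed within the scatter. On that basis no step beyond the scatter is expected in this assay from compound 3 to compound 4, and the estimate for compound 4 is 45000 nM with a range from 15000 nM to 130000 nM. The step this estimate means, a 1.3-fold lower number from compound 3 to compound 4 (0.11 log units; within the scatter), is expected to be small, reflecting that compound 3 at 57600 nM is the closest measured reference.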

Compound 4, concentration for 50% growth inhibition: 31500 nM
Compound 4: middle estimate off by 1.4-fold (0.15 log units), on the high side, within the range that was stated.
By their numbers in this assay, from the lowest: compounds 2, 1, 4 and 3 (each within the scatter of the next, the first and the last beyond it).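

In this assay, the swap to a ring amine gives a 1.8-fold lower number from compound 3 to compound 4 (0.26 log units; within the scatter), so piperidin-1-yl, with 6 heavy atoms and one six-membered non-aromatic ring, reads the same as dimethylamino, with 3 heavy atoms and no ring, on a saturated chain carbon bound to an amide-type nitrogen in a ring. For the compounds shown here, until now, the only reading at this place was a 1.7-fold lower number from compound 1 to compound 2 (0.22 log units; within the scatter), a swap between two open-chain amines on the core of compound 1; there is now a second reading, on the core of compound 3, and it involves a ring. Both steps stay within the scatter, so neither of these two amine swaps separates its pair in this assay, though two pairs establish no general rule for this place, and no measurement on hand accounts for the result.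

On these data alone, it remains open whether an amine ring carrying a second hetero atom, such as morpholin-4-yl or piperazin-1-yl, or a longer chain between the ring nitrogen and the amine, would give a step beyond the scatter. Also open is how piperidin-1-yl reads on the core of compound 1, where only diethylamino and dimethylamino are shown.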